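The source may hold more compounds than are shown below. What is called first, only, known or untested is meant among the compounds shown, and "the series" means these compounds.

In an assay on HEK293 cells for inhibition of Steryl-sulfatase (Homo sapiens), tested at 0.1 uM (on this read-out lower numbers stand for a weaker effect and higher numbers for a stronger effect at the one concentration tested), compound 3 `CCN(Cc1ccccc1)c1ccc(C(=O)N2CCc3ccc(OS(N)(=O)=O)cc3C2)cc1` gives 66.9%, the second highest of the three numbers: compound 2 `CCN(Cc1ccc(Br)cc1)c1ccc(C(=O)N2CCc3ccc(OS(N)(=O)=O)cc3C2)cc1` gives 78.2% and compound 1 `CCN(Cc1cccnc1)c1ccc(C(=O)N2CCc3ccc(OS(N)(=O)=O)cc3C2)cc1` gives 35.7%. The measured steps in this assay are a number 31.2 percentage points higher from compound 1 to compound 3 (beyond the scatter), a number 42.5 percentage points higher from compound 1 to compound 2 (beyond the scatter) and a number 11.3 percentage points lower from compound 2 to compound 3 (beyond the scatter). Compound 4 `CCCN(CCC)c1ccc(C(=O)N2CCc3ccc(OS(N)(=O)=O)cc3C2)cc1` differs from compound 3 in that (dipropylamino in place of benzyl(ethyl)amino on an aromatic carbon). Within the data shown here, none of the measured steps removes the ring from the group on the nitrogen; they only exchange one ring for another or add bromo, so they give no direct guide to this change. As the larger steps all involve that ring, a lowering beyond the scatter is expected for compound 4, a number 18.9 percentage points lower from compound 3 to compound 4 (beyond the scatter). In this assay compound 4 is estimated at 48%, within 25% to 72%.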

Compound 4, a percentage reported as inhibition, at one concentration (the size of the read-out at that concentration, not a potency): 36.6%
For compound 4 the middle estimate is 11.4 percentage points above the measured one; low and high end bracket the measured number.
By their numbers in this assay, from the lowest: compounds 1 and 4 (each within the scatter of the next); then compound 3; then compound 2.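

In this assay, with no ring left in the group on the nitrogen, dipropylamino gives a number 30.3 percentage points lower from compound 3 to compound 4 (beyond the scatter) and a number 41.6 percentage points lower from compound 2 to compound 4 (beyond the scatter) in this series. Set against ethyl((pyridin-3-yl)methyl)amino, dipropylamino gives a number 0.9 percentage points higher from compound 1 to compound 4 (within the scatter) and the two groups cannot be told apart at this position. No measured data on these compounds accounts for these steps.

Open, on these data alone, is whether the loss follows from the missing ring or from the change of chains on the nitrogen. Also open, as far as these compounds go, is how a longer chain such as dibutylamino, or a chain ending in a carboxylic acid, would read at this position.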